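Toward an aryl amide on the hexafluoro-carbinol naphthalene core

A few compounds are considered here, and "the series" means these few. Any claim that something is new, unique, unknown or untested is made for them only; others in the source may bear on it.

Measured compounds:
compound 1 `CC(=O)Nc1c(C(O)(C(F)(F)F)C(F)(F)F)ccc2ccccc12`: 18 nM
compound 2 `C/C=C/C(=O)Nc1c(C(O)(C(F)(F)F)C(F)(F)F)ccc2ccccc12`: 72 nM
compound 3 `COCC(=O)Nc1c(C(O)(C(F)(F)F)C(F)(F)F)ccc2ccccc12`: 213 nM

Three amides sharing the core of compound 1 have been tested in an assay on LtK cells with ATP-sensitive inward rectifier potassium channel 11 (Homo sapiens) as the target; a higher number here means that more compound is needed for the effect, a lower number that less compound is needed. Compound 3 stands at the highest number of the three. Its nearest neighbour is compound 2, with a 3.0-fold higher number from compound 2 to compound 3 (0.47 log units; beyond the scatter); its furthest is compound 1, with a 12-fold higher number from compound 1 to compound 3 (1.07 log units; beyond the scatter).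

Compound 4 `O=C(Nc1c(C(O)(C(F)(F)F)C(F)(F)F)ccc2ccccc12)c1ccc(C(F)(F)F)cc1` has not yet been measured in this assay. It differs from compound 3 in one place: 4-(trifluoromethyl)phenyl in place of methoxymethyl on a carbonyl carbon. Among the measured compounds shown here, two measured steps touch the same carbonyl carbon. Replacing methyl with prop-1-en-1-yl gave a 4.0-fold higher number from compound 1 to compound 2 (0.60 log units; beyond the scatter), and adding methoxy gave a 12-fold higher number from compound 1 to compound 3 (1.07 log units; beyond the scatter). For the measured compounds named here, both moved the number upward, so the data give no step in which a group entering here has lowered the number. Compound 4 removes the methoxy group that accompanied the largest upward step, which argues for a number lower than that of compound 3, while the size of the entering group is without precedent among the measured compounds, so the estimate carries a wide range.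

Compound 4 is therefore expected to give a modest downward step, a 2.4-fold lower number from compound 3 to compound 4 (0.37 log units; beyond the scatter). The estimate for compound 4 in this assay is 90 nM, with a range from 20 nM to 400 nM.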

Compound 4, half-maximal effective concentration: 160 nM
For compound 4 the middle estimate is 1.8-fold (0.25 log units) below the measured one, within the range that was stated.
By their numbers in this assay, from the lowest: compound 1; then compound 2; then compounds 4 and 3 (each within the scatter of the next).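

In this assay, 4-(trifluoromethyl)phenyl on the carbonyl carbon cannot be told apart from methoxymethyl, with a 1.3-fold lower number from compound 3 to compound 4 (0.12 log units; within the scatter), even though the entering group brings a six-membered aromatic ring and no hydrogen-bond acceptor. This position therefore accepts an aromatic ring without a separation from compound 3, yet the ring does not bring the number back towards that of the methyl amide: the data show a 2.2-fold higher number from compound 2 to compound 4 (0.35 log units; beyond the scatter) and an 8.9-fold higher number from compound 1 to compound 4 (0.95 log units; beyond the scatter), so all three replacements of methyl measured here raise the number and compound 1 keeps the lowest number of the four. The compounds shown offer no measurement that could account for these steps.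

As far as these compounds go, how much of the number of compound 4 belongs to the ring and how much to its trifluoromethyl group remains open, and a plain phenyl on the same carbonyl carbon would address that question. Also open, from the compounds shown here alone, is whether any group on this carbon can go below the methyl amide, for instance ethyl, cyclopropyl or an amine.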